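Pyridazinone amides: bromo-fluorophenyl variant of compound 2

The compounds below may be only part of what the source reports. "The series", "measured", "known", "first", "only" and "open" are said of these compounds alone.

Two members of this series have numbers in a functional assay on MCF7 cells (Homo sapiens) for cytotoxicity, read by MTT assay, with a stated time of 72 h; on this read-out lower numbers stand for stronger inhibition and higher numbers for weaker inhibition. Compound 1 `Cn1ccc2c(Oc3ccc(NC(=O)c4nn(-c5ccc(Br)cc5)ccc4=O)cc3F)ccnc21` carries an N-methylated bicyclic ether and a bromophenyl group on the pyridazinone-type nitrogen; in this assay compound 1 gives 33600 nM. Compound 2 `Cc1cc(=O)n(-c2cccc(F)c2)nc1C(=O)Nc1ccc(Oc2ncnc3[nH]ccc23)cc1`, with a different bicyclic ether and a 3-fluorophenyl group on that nitrogen, gives 9670 nM in this assay, the lower of the two numbers, and the gap to compound 1 lies beyond the usual scatter. Compound 2 therefore stands as the reference point for the next change.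

Compound 3 `Cc1cc(=O)n(-c2ccc(Br)cc2F)nc1C(=O)Nc1ccc(Oc2ncnc3[nH]ccc23)cc1` differs from compound 2 in one place: 4-bromo-2-fluorophenyl in place of 3-fluorophenyl on an aromatic nitrogen. For the measured compounds named here, no measured pair in this set isolates this change, so the size of the step is open. The expected step from compound 2 to compound 3 is a 1.4-fold lower number from compound 2 to compound 3 (0.14 log units; within the scatter), that is, no change clearly beyond the scatter, with a slight lean toward a lower number. On that basis compound 3 is estimated at 7000 nM in this assay, with a range from 2500 nM to 20000 nM.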

Compound 3, half-maximal inhibitory concentration: 3210 nM
Estimate against measurement, compound 3: 2.2-fold (0.34 log units) above; the measured number falls inside the stated range.
By their numbers in this assay, from the lowest: compound 3; then compound 2; then compound 1.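

For the compounds shown here, exchanging 3-fluorophenyl for 4-bromo-2-fluorophenyl on the aromatic nitrogen gives, in this assay, a 3.0-fold lower number from compound 2 to compound 3 (0.48 log units; beyond the scatter) as the first single-place step, so the number at this position does respond to the aryl group it carries. Compounds 1 and 2 could not show this, since they differ in more than one place and their gap cannot be assigned to the aryl group alone. The step is modest and the exchange alters the ring in two ways at once, with the fluorine in a different place and a bromine added, and no measurement shown bears on why the number falls.

Still open, on these data alone, is how the step divides between the bromine and the shifted fluorine, and whether an aryl group with an amine or a carboxylic acid in place of the bromine would move the number further in either direction. Also open is whether the same exchange gives a step of similar size on the core of compound 1, with its N-methylated bicyclic ether, since no single-place pair on that core is shown.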